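Aryl substitution at the fused core: compound 1 to 3

The compounds below may be only part of what the source reports. "The series", "measured", "known", "first", "only" and "open" are said of these compounds alone.

Compound 1 `COc1cc(-n2cnc3ccc(-c4cc(F)ccc4F)cc32)cc(OC)c1OC` carries a 2,5-difluorophenyl on the shared core; in a functional assay on A549 cells (Homo sapiens) for antiproliferative activity, read by MTT assay, with a stated time of 72 h (a higher number here means a weaker inhibitor, a lower number a stronger inhibitor), compound 1 gives 7940 nM, the higher of the two numbers measured. Compound 2 `COc1cc(-n2cnc3ccc(-c4cccc(N)c4)cc32)cc(OC)c1OC` bears 3-aminophenyl at the same place; in this assay compound 2 gives 640 nM, and the step of a 12-fold lower number from compound 1 to compound 2 (1.09 log units; beyond the scatter) shows that the substitution pattern of this aryl ring moves the number markedly.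

Compound 3 `COc1cc(-n2cnc3ccc(-c4ccc(Cl)cc4)cc32)cc(OC)c1OC` is not yet measured. Its change from compound 1 is 4-chlorophenyl in place of 2,5-difluorophenyl on an aromatic carbon. For the measured compounds named here, no measured step covers a halogen-for-halogen exchange of this kind; the only comparison available, from compound 1 to compound 2, concerns a different entering group, so its direction cannot be transferred. A step of comparable size in either direction is therefore possible, and the range must stay wide. The expected step is a 2.3-fold lower number from compound 1 to compound 3 (0.36 log units; beyond the scatter), with compound 3 estimated at 3500 nM and a likely range from 700 nM to 15000 nM.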

Compound 3, half-maximal inhibitory concentration: > 10000 nM
Compound 3: no number, only a limit; the forecaster's own chance of this, stated with the estimate: 5%; at least 2.8-fold (0.45 log units) between middle value and limit.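

Compound 3 stands at a limit of the assay, not at a number: the limit of > 10000 nM in this assay, at which 1 of the 3 values shown sits. The change reads as an at least 15-fold higher number from compound 2 to compound 3 (1.19 log units; beyond the scatter), so the low number of compound 2 does not carry over to 4-chlorophenyl, and this position separates these two aryl groups widely. As far as these compounds go, the other change reads as an at least 1.2-fold higher number from compound 1 to compound 3 (0.10 log units; that floor lies within the scatter), which gives only a floor, so the distance between the 2,5-difluorophenyl and 4-chlorophenyl compounds stays unknown and no order can be set between them.

Still open, from the compounds shown here alone, is whether the low number of compound 2 depends on the amine itself or on the 3-aminophenyl pattern as a whole. A hydroxyl or a carboxylic acid on the phenyl ring in place of that amine would bear on this question.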